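Cytotoxicity of naphthyl ether sulfonamides and a nitrile analogue

The source may hold more compounds than are shown below. What is called first, only, known or untested is meant among the compounds shown, and "the series" means these compounds.

Compound 1, `Cc1cc(S(N)(=O)=O)ccc1NC(=O)COc1ccc(F)cc1Oc1cccc2ccccc12`, in an ADME assay on C8166 cells (Homo sapiens) for cytotoxicity, read by MTT assay (on this read-out higher numbers stand for lower toxicity in this test and lower numbers for higher toxicity in this test), gives 33100 nM.
Compound 2, `Cc1cc(S(N)(=O)=O)ccc1NC(=O)COc1ccc(F)cc1Oc1cc2ccccc2cc1C`, in this assay gives 66900 nM.
Compound 3, `Cc1cc(S(N)(=O)=O)ccc1NC(=O)COc1ccc(F)cc1Oc1ccc2ccccc2c1C`, in this assay gives 56100 nM.

Compound 3 stands second highest of the three numbers. Its nearest neighbour is reached by the step of a 1.2-fold lower number from compound 2 to compound 3 (0.08 log units; within the scatter), and the furthest by the step of a 1.7-fold higher number from compound 1 to compound 3 (0.23 log units; within the scatter); both steps lie within the scatter, so the three measured compounds are not clearly separated except by the step of a 2.0-fold higher number from compound 1 to compound 2 (0.31 log units; beyond the scatter), which is modest.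

Compound 4, `Cc1cc(S(N)(=O)=O)ccc1NC(=O)COc1ccc(F)cc1Oc1ccc2cc(C#N)ccc2c1`, differs from compound 3 in one place: 6-cyanonaphthalen-2-yl in place of 1-methylnaphthalen-2-yl on an oxygen on an aromatic ring. The measured steps that bear on this position are a 2.0-fold higher number from compound 1 to compound 2 (0.31 log units; beyond the scatter), a 1.7-fold higher number from compound 1 to compound 3 (0.23 log units; within the scatter) and a 1.2-fold lower number from compound 2 to compound 3 (0.08 log units; within the scatter), all of which exchange one naphthyl group for another and all of which are small; none of them introduces a nitrile, so the new group is not covered by any measured step. Given that every exchange of the naphthyl group so far moved the number little, the step of a 1.1-fold lower number from compound 3 to compound 4 (0.05 log units; within the scatter) is expected to stay within the scatter. Compound 4 in this assay is therefore estimated at 50000 nM, with a range from 20000 nM to 125000 nM.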

Compound 4, half-maximal cytotoxic concentration: > 395000 nM
Compound 4: a limit, no number (the forecaster's own chance of this, stated with the estimate: 10%); middle value at least 7.9-fold (0.89 log units) from the limit.
By their numbers in this assay, from the lowest: compounds 1, 3 and 2 (each within the scatter of the next, the first and the last beyond it). At a limit, above all of these: compound 4.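

In this assay compound 4 reads only as a limit: the limit of > 395000 nM in this assay, at which 1 of the 4 values shown sits. Exchanges among the naphthyl groups on an oxygen on an aromatic ring had so far moved the number little, but 6-cyanonaphthalen-2-yl brings clear steps towards lower toxicity in this test: an at least 7.0-fold higher number from compound 3 to compound 4 (0.84 log units; beyond the scatter), an at least 5.9-fold higher number from compound 2 to compound 4 (0.77 log units; beyond the scatter) and an at least 11-fold higher number from compound 1 to compound 4 (1.07 log units; beyond the scatter). All three rest on the limit, so they give a minimum size for the change and not a measured one.

The compounds shown leave open whether the nitrile itself carries this change, or whether plain naphthalen-2-yl, without the nitrile or a methyl group, would read the same. They also leave open how a carboxamide or an aminomethyl group in place of the nitrile would read.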